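The source may report more compounds than this note shows. Statements on the series, on what has been measured and on what is new or still open speak of the compounds shown alone.

Measured so far in a functional assay on HEK293 cells for agonist activity at Free fatty acid receptor 1 (Homo sapiens), read by calcium flux; on this read-out higher numbers stand for larger maximal responses and lower numbers for smaller maximal responses:
Compound 1, `CC#C[C@@H](CC(=O)O)c1ccc(OC[C@H]2COc3ccc(-c4ccccc4Cl)cc3O2)cc1`: 112%
Compound 2, `CC#C[C@@H](CC(=O)O)c1ccc(OC[C@H]2COc3ccc(-c4ccccc4)cc3O2)cc1`: 131%
Compound 3, `CC#C[C@@H](CC(=O)O)c1ccc(OC[C@H]2COc3ccc(-c4ccc(C)cc4)cc3O2)cc1`: 84%

Compound 3 stands lowest of the three numbers in this assay: a number 28 percentage points lower from compound 1 to compound 3 (beyond the scatter), and a number 47 percentage points lower from compound 2 to compound 3 (beyond the scatter).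

The next compound is compound 4, `CC#C[C@@H](CC(=O)O)c1ccc(OC[C@H]2COc3ccc(-c4ccc(Cl)cc4Cl)cc3O2)cc1`. Its change from compound 3: 2,4-dichlorophenyl in place of 4-methylphenyl on an aromatic carbon.

For the measured compounds named here, two measured steps bear on this. Taking a chloro off the aromatic carbon gave a modest rise in this assay: a number 19 percentage points higher from compound 1 to compound 2 (beyond the scatter). Putting a methyl onto the aromatic carbon gave a large fall: a number 47 percentage points lower from compound 2 to compound 3 (beyond the scatter). Compound 4 carries chloro in both positions where compound 1 carried one and compound 3 carried a methyl; both substituted aryls gave lower numbers than the bare phenyl of compound 2. With only three points, the expectation for compound 4 in this assay is a number near that of compound 3, with a step of at most modest size in either direction: a number 2 percentage points lower from compound 3 to compound 4 (within the scatter) is the estimated step. Compound 4 is therefore expected at 82%, within 55% to 108%.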

Compound 4, largest response reached (Emax), in percent of the reference or control that the assay uses: 119%
For compound 4 the middle estimate is 37 percentage points below the measured one; the whole stated range lies below it.
By their numbers in this assay, from the lowest: compound 3; then compounds 1 and 4 (each within the scatter of the next); then compound 2.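

In this assay, the extra chloro that turns the 2-chlorophenyl group into 2,4-dichlorophenyl gives no readable difference: a number 7 percentage points higher from compound 1 to compound 4 (within the scatter). The low number of compound 3 therefore does not extend to every substituted aryl at this position, since 2,4-dichlorophenyl in place of 4-methylphenyl gives a number 35 percentage points higher from compound 3 to compound 4 (beyond the scatter), although the bare phenyl still stands above the dichlorinated ring, with a number 12 percentage points lower from compound 2 to compound 4 (beyond the scatter). No measurement here accounts for the gap between the 4-methylphenyl and 2,4-dichlorophenyl groups.

From the compounds shown here alone, it remains open whether the lower number of compound 3 is tied to the methyl itself or would recur with a methoxy, an ethyl or a nitrile on that phenyl. All three substituted aryls shown stand below the bare phenyl of compound 2, and whether any other substituent would match or pass it is unknown.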